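The source may report more compounds than this note shows. Statements on the series, on what has been measured and on what is new or still open speak of the compounds shown alone.

Of the compounds shown here, two built on one shared core have so far been measured in a functional assay on cells (T-cell, Mus musculus) for inhibition; on this read-out lower numbers stand for stronger inhibition and higher numbers for weaker inhibition. Compound 1 `O=C(/C=C/c1ccccc1)Nc1ccc2c(c1)COC2=O` gives 7240 nM in this assay. Compound 2 `CC(C)(C)NC(=O)C(=O)Nc1ccc2c(c1)COC2=O` gives 3400 nM in this assay, the lower of the two numbers, and the gap to compound 1 lies beyond the usual scatter of repeated measurements. Compound 3 `Cc1ccccc1NC(=O)C(=O)Nc1ccc2c(c1)COC2=O` has not yet been measured. Its structure differs from compound 2 in a single place: 2-methylphenyl in place of tert-butyl on an amide-type nitrogen. Within the data shown here, no step between compounds differing in only one place has been measured, so nothing among the two known numbers shows what this particular exchange does. The expected step is therefore a 1.4-fold lower number from compound 2 to compound 3 (0.13 log units; within the scatter), a small one that may well fall within the scatter. Compound 3 is accordingly estimated at 2500 nM in this assay, with a range from 700 nM to 9000 nM to reflect the uncertainty.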

Compound 3, half-maximal inhibitory concentration: 5510 nM
Compound 3: the middle estimate sits 2.2-fold (0.34 log units) below what was measured, and the stated range covers the measured number.
By their numbers in this assay, from the lowest: compounds 2, 3 and 1 (each within the scatter of the next, the first and the last beyond it).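

Among these compounds, this is the first step measured at this position. In this assay, placing 2-methylphenyl instead of tert-butyl on the amide-type nitrogen gives a 1.6-fold higher number from compound 2 to compound 3 (0.21 log units; within the scatter) and so stays within the usual scatter of repeated measurements. The position therefore takes a six-membered aromatic ring of carbon in place of a group with no ring, and a larger group with 7 heavy atoms instead of 4, with no change that can be told from scatter. Nothing available gives a reason for this outcome.

It remains open whether the methyl on the ring matters at all, since plain phenyl is not among the compounds shown. As far as these compounds go, it is equally open whether a group such as an amine, a carboxylic acid or a longer chain on this nitrogen would move the number beyond the scatter.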